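The source may hold more compounds than are shown below. What is called first, only, known or untested is meant among the compounds shown, and "the series" means these compounds.

Two compounds built on a shared core were tested in a functional assay on the whole organism with Homo sapiens as the target, read by hemolysis; a higher number here means a weaker inhibitor, a lower number a stronger inhibitor. Compound 1 `CC1(C)Cc2c(Oc3ccccc3)cc(C=O)cc2O1` reaches only the limit > 1120000 nM in this assay. Compound 2 `COc1cc(C(=O)O)cc2c1CC(C)(C)O2` likewise gives only the limit > 1350000 nM in this assay, so no number marks where compound 2 stands. Compound 3 `CC1(C)Cc2c(Oc3ccccc3)cc(C(=O)O)cc2O1` differs from compound 2 by one change, (phenyl in place of methyl on an oxygen on an aromatic ring), phenyl in place of methyl on an oxygen on an aromatic ring. Among the compounds with values here, no step between measured compounds is known that would guide this change. The estimated step of a number no higher from compound 2 to compound 3 (the limit leaves the size open) is expected to be none beyond the scatter. Compound 3 is therefore expected to give 1350000 nM, within 500000 nM to 5000000 nM, most likely again as a limit.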

Compound 3, half-maximal inhibitory concentration: > 1050000 nM
Compound 3: only a limit was reported; the forecaster's own chance of this, stated with the estimate: 85%; the middle value lies beyond the limit too.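

Within the data shown here, compound 1, compound 2 and compound 3 each give only a limit in this assay; no step from compound 1 or compound 2 to compound 3 can be read. Going by these compounds, whether phenoxy in place of methoxy changes inhibition at all stays open.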